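The compounds below may be only part of what the source reports. "The series", "measured", "known", "first", "only" and "open" are said of these compounds alone.

Measured in a functional assay on A549 cells (Homo sapiens) for antiproliferative activity, read by MTT assay, with a stated time of 72 h; on this read-out higher numbers stand for weaker inhibition and lower numbers for stronger inhibition:
Compound 1 `NC1=NC2(CCSCC2)N(OCCCOc2ccc(Cl)c(Cl)c2)C(N)=N1`: 1 nM
Compound 2 `Cc1cc(C)cc(OCCCON2C(N)=NC(N)=NC23CCOCC3)c1`: 710 nM
Compound 3 `NC1=NC2(CCSCC2)N(OCCCOc2cccc(Br)c2)C(N)=N1`: 50 nM

Compound 2 has the highest number of the three, beyond the scatter from both others. Compound 4 `NC1=NC2(CCOCC2)N(OCCCOc2ccc(Br)cc2)C(N)=N1` keeps the core of compound 2 and carries 4-bromophenyl in place of 3,5-dimethylphenyl on an oxygen on a saturated carbon. Among the compounds with values here, the only measured step at this place is large, a 50-fold higher number from compound 1 to compound 3 (1.70 log units; beyond the scatter), but it sits on the different core of compound 1, so it bears only indirectly. It shows that this assay responds strongly to this group. With a 3-bromophenyl group, compound 3 gives 50 nM. A moderate move to a lower number, beyond the scatter, is therefore expected. The expected step is a 5.9-fold lower number from compound 2 to compound 4 (0.77 log units; beyond the scatter). The estimate for compound 4 is 120 nM, with an expected range of 20 nM to 600 nM.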

Compound 4, half-maximal inhibitory concentration: 280 nM
Compound 4: middle estimate off by 2.3-fold (0.37 log units), on the low side, within the range that was stated.
By their numbers in this assay, from the lowest: compound 1; then compound 3; then compound 4; then compound 2.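

In this assay, the aryl group on the oxygen also moves the number on the core of compound 2: 4-bromophenyl in place of 3,5-dimethylphenyl gives a 2.5-fold lower number from compound 2 to compound 4 (0.40 log units; beyond the scatter). This step is modest, while a 50-fold higher number from compound 1 to compound 3 (1.70 log units; beyond the scatter) is large, but that step is a different change on a different core, so the two sizes do not rank. Nothing available bears on the reason for the new step.

Open: how the two cores compare under one identical aryl group, and what an amine or carboxylic acid on the phenyl ring, or a longer chain, would do.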